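From 4-Fluorophenyl to 3-Chlorophenyl in a Weak Growth Inhibitor

The compounds below may be only part of what the source reports. "The series", "measured", "known", "first", "only" and "open" are said of these compounds alone.

In a functional assay on SiHa cells (Homo sapiens) for inhibition, read by sulforhodamine B assay (a higher number here means a weaker inhibitor of growth, a lower number a stronger inhibitor of growth), compound 1 (`COc1ccc(-c2ccc(-c3ccc(-c4nc5cc(C)ccc5[nH]4)cc3)cc2)cc1OC`) gives 3510 nM and compound 2 (`Fc1ccc(-c2ccc(-c3ccc(-c4nc5ccccc5[nH]4)cc3)cc2)cc1`) gives 29700 nM so far. Compound 2 thus holds the higher of the two numbers, which makes it the weaker inhibitor of the pair, and the gap to compound 1 lies beyond the usual scatter. These two compounds differ in more than one place, so their gap cannot be pinned on any single group.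

Compound 3 (`Clc1cccc(-c2ccc(-c3ccc(-c4nc5ccccc5[nH]4)cc3)cc2)c1`) has not been measured yet. It is compound 2 with 3-chlorophenyl in place of 4-fluorophenyl on an aromatic carbon and nothing else changed. Within the data shown here, no measured pair shows what such a swap does, so the expectation starts from compound 2 at 29700 nM and allows only a modest move. In this assay the estimated step is small and toward a lower number, staying within the scatter (a 1.7-fold lower number from compound 2 to compound 3 (0.22 log units; within the scatter)) rather than making a large jump. For compound 3 the expected value is 18000 nM with an estimated range of 6000 nM to 50000 nM for a single measurement.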

Compound 3, concentration for 50% growth inhibition: 100000 nM
For compound 3 the middle estimate is 5.6-fold (0.74 log units) below the measured one, and the stated range ends below it.
By their numbers in this assay, from the lowest: compound 1; then compound 2; then compound 3.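

In this assay, among these compounds, this is the first single-place comparison, and the swap of 4-fluorophenyl for 3-chlorophenyl gives a 3.4-fold higher number from compound 2 to compound 3 (0.53 log units; beyond the scatter). This position is therefore not indifferent to the choice of aryl group, even though the two groups have the same count of heavy atoms, the same single aromatic ring of carbon only, no hydrogen-bond donors or acceptors, and no net charge. No measurement here explains the loss of growth inhibition, so the step stands as an observation without an established cause.

The compounds shown leave open whether the step follows from exchanging fluorine for chlorine or from moving the halogen on the ring, as both changes happen together; 4-chlorophenyl and 3-fluorophenyl at this position would separate the two. As far as these compounds go, it also remains open whether a group of a different kind here, such as an amine or a carboxylic acid on the phenyl ring, would lower the number, and compound 1 cannot settle this as it differs from compound 2 in more than one place.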